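Compound 1 loses its acetyl group

The compounds below may be only part of what the source reports. "The series", "measured", "known", "first", "only" and "open" are said of these compounds alone.

Values in an ADME assay on THP-1 cells (Homo sapiens) for cytotoxicity, read by flow cytometry and propidium iodide staining, with a stated time of 72 h; a lower number here means a stronger inhibitor, a higher number a weaker inhibitor:
compound 1 `CC(=O)Nc1ccc2oc(-c3ccccc3)c(O)c(=O)c2c1`: 36000 nM
compound 2 `COc1ccc(-c2oc3ccc(NC(C)=O)cc3c(=O)c2O)cc1`: 9000 nM
compound 3 `CC(=O)Nc1ccc2oc(-c3ccc(C(F)(F)F)cc3)c(O)c(=O)c2c1`: > 50000 nM, a limit of the assay

Of the two actual numbers in this assay, compound 1 has the higher, 36000 nM, and its nearest neighbour is compound 2: a 4.0-fold lower number from compound 1 to compound 2 (0.60 log units; beyond the scatter). The value of compound 3 is a limit and gives no exact position.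

The next compound to be tested is compound 4 `Nc1ccc2oc(-c3ccccc3)c(O)c(=O)c2c1`, which differs from compound 1 by hydrogen in place of acetyl on a nitrogen on an aromatic ring, or acetamido to amino: hydrogen in place of acetyl on a nitrogen on an aromatic ring.

Within the data shown here, none of the measured steps touches this nitrogen, so the direction of the change has not been measured. All three replace a group on an aromatic carbon and can serve only as a guide to size. They are a 4.0-fold lower number from compound 1 to compound 2 (0.60 log units; beyond the scatter), an at least 1.3-fold higher number from compound 1 to compound 3 (0.14 log units; that floor lies within the scatter) and an at least 5.5-fold higher number from compound 2 to compound 3 (0.74 log units; beyond the scatter).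

Among the measured compounds shown here, the one step to an actual number, a 4.0-fold lower number from compound 1 to compound 2 (0.60 log units; beyond the scatter), goes downward, and compound 1 at 36000 nM already lies close to the limit of > 50000 nM in this assay, at which 1 of the 3 values shown sits. A small move to a lower number is therefore expected, with little confidence in its direction: a 2.4-fold lower number from compound 1 to compound 4 (0.38 log units; beyond the scatter). For compound 4 the estimated value is 15000 nM, with an expected range from 4000 nM to 50000 nM.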

Compound 4, half-maximal inhibitory concentration: 27000 nM
Estimate against measurement, compound 4: 1.8-fold (0.26 log units) below; the measured number falls inside the stated range.
By their numbers in this assay, from the lowest: compound 2; then compounds 4 and 1 (each within the scatter of the next). At a limit, above all of these: compound 3.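

Where every earlier step changed a group on an aromatic carbon, this one acts on a nitrogen on an aromatic ring, and in this assay hydrogen in place of acetyl gives a 1.3-fold lower number from compound 1 to compound 4 (0.12 log units; within the scatter). Compound 1 and compound 4 therefore cannot be told apart in this assay, so the acetyl, with its 3 heavy atoms and its hydrogen-bond acceptor, can be lost from this nitrogen without a readable shift on the shared core. The only step from compound 1 to an actual number that lies beyond the scatter thus remains the one on the aromatic carbon, a 4.0-fold lower number from compound 1 to compound 2 (0.60 log units; beyond the scatter), while this nitrogen has so far shown no such step.

As far as these compounds go, it remains open whether the free amine behaves the same way when methoxy or trifluoromethyl sits on the aromatic carbon, and what a longer acyl chain, a sulfonamide or a carboxylic acid on this nitrogen would do. Compound 3 is the only compound shown at a limit, so any upward move from this nitrogen might be read only in part: the limit of > 50000 nM in this assay, at which 1 of the 4 values shown sits.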